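This account rests on a few compounds, and the source may have more. Where it says the series, first, only, none or still open, it means among the compounds named here.

In a functional assay on FL5.12 cells (Mus musculus) for cytotoxicity, read by flow cytometry and propidium iodide staining, with a stated time of 48 h (on this read-out higher numbers stand for weaker inhibition and lower numbers for stronger inhibition), compound 1 `CCCCCCCCc1ccc(C(=O)C[C@@H]2CCCN2)cc1` gives 2500 nM and compound 2 `CCCCCCCCc1ccc(C(C[C@@H]2CCCN2)OC)cc1` gives 3000 nM on the same read-out. Compound 3 `CCCCCCCCc1ccc(CC(=O)[C@@H]2C[C@@H](OP(=O)(O)O)CN2)cc1` gives 25000 nM as the highest number of the three, which means the weakest inhibition here. Compound 4 `CCCCCCCCc1ccc(CC(=O)[C@H]2C[C@H](OP(=O)(O)O)CN2)cc1` has the same atoms and bonds as compound 3 but is its mirror image (the two compounds have the same atoms and bonds and differ only in configuration as drawn: 2 of 2 stereo elements differ (all stereocentres are inverted: mirror images); a stereocentre at a saturated ring carbon is drawn S in compound 3 and R in compound 4; a stereocentre at a saturated ring carbon is drawn R in compound 3 and S in compound 4). Going by the values given here, no measured pair shows what such an inversion does, so the expectation rests on compound 3 at 25000 nM and no step beyond the scatter is expected in this assay for now. The estimated change a 1.3-fold lower number from compound 3 to compound 4 (0.10 log units; within the scatter) is therefore small. For compound 4 the expected value is 20000 nM with an estimated range from 7000 nM to 45000 nM in this test.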

Compound 4, half-maximal inhibitory concentration: 25300 nM
Compound 4: the middle estimate sits 1.3-fold (0.10 log units) below what was measured; measured number inside the range.
By their numbers in this assay, from the lowest: compounds 1 and 2 (each within the scatter of the next); then compounds 3 and 4 (each within the scatter of the next).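

Inverting both ring stereocentres together gives a 1.0-fold higher number from compound 3 to compound 4 (0.01 log units; within the scatter) in this assay, the first measured pair to show what such an inversion does. For these mirror images, the read-out does not separate the two configurations, and nothing else varies within the pair: the fact that compounds 3 and 4 differ only in the configuration as drawn

The compounds shown leave open whether inverting only one of the two stereocentres would also stay within the scatter. They also leave open whether the two configurations would remain alike with a carboxylic acid in place of the phosphate group.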